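Chloro Analogue of Compound 1 Ahead of Measurement

This account rests on a few compounds, and the source may have more. Where it says the series, first, only, none or still open, it means among the compounds named here.

Measured compounds:
compound 1, `CC1CC(=O)N(CC(=O)N2CCN(c3ccccc3)CC2)C1=O`: 300 mg/kg
compound 2, `CC1CC(=O)N(CC(=O)N2CCN(c3ccc(F)cc3)CC2)C1=O`: 300 mg/kg
compound 3, `CC1CC(=O)N(CC(=O)N2CCN(c3ccc(Cl)c(Cl)c3)CC2)C1=O`: 300 mg/kg

In a functional assay on the whole organism (strain CD1) with Mus musculus as the target, in the maximal electroshock model, with a stated time of 0.5 h (a higher number here means that more compound is needed for the effect, a lower number that less compound is needed), compound 1 gives 300 mg/kg, level with compound 2 and compound 3. The step of no change at the digits printed from compound 1 to compound 2 (within the scatter), the step of no change at the digits printed from compound 1 to compound 3 (within the scatter) and the step of no change at the digits printed from compound 2 to compound 3 (within the scatter) all stay within the scatter. Compound 4, `CC1CC(=O)N(CC(=O)N2CCN(c3ccc(Cl)cc3)CC2)C1=O`, differs from compound 1 by chloro in place of hydrogen on an aromatic carbon. Going by the values given here, the steps that bear on this change put fluoro or 3,4-dichlorophenyl into the same region of the shared core and moved nothing beyond the scatter, so a chloro in that place is expected to leave the minimum effective dose where it is. The expected step of no change at the digits printed from compound 1 to compound 4 (within the scatter) is accordingly no change beyond the scatter. Compound 4 is therefore estimated at 300 mg/kg, with a range from 150 mg/kg to 600 mg/kg.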

Compound 4, minimum effective dose: 100 mg/kg
For compound 4 the middle estimate is 3.0-fold (0.48 log units) above the measured one; the measured number lies below the stated range.
By their numbers in this assay, from the lowest: compound 4; then compounds 1, 2 and 3 (each within the scatter of the next).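

In this assay, the place para to a large group proves sensitive to which halogen stands there: a 3.0-fold lower number from compound 1 to compound 4 (0.48 log units; beyond the scatter) and a 3.0-fold lower number from compound 2 to compound 4 (0.48 log units; beyond the scatter) both lie beyond the scatter, so chloro differs from both hydrogen and fluoro. Read from the other side, a 3.0-fold lower number from compound 3 to compound 4 (0.48 log units; beyond the scatter) also lies beyond the scatter, so 3,4-dichlorophenyl does not keep what 4-chlorophenyl shows. The earlier level values gave no sign that this place could respond at all.

No measurement at hand accounts for these steps. On these data alone, whether bromo or methoxy in the same place would follow chloro stays open.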